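A few compounds are considered here, and "the series" means these few. Any claim that something is new, unique, unknown or untested is made for them only; others in the source may bear on it.

Of the compounds shown here, three on a shared core have been tested in a toxicity assay on A549 cells (Homo sapiens) for cytotoxicity, read by luminescence and CellTiter-Glo, with a stated time of 48 h; a lower number here means that less compound is tolerated, a higher number that more compound is tolerated. Compound 1 `CCCCOc1ccc(-c2c(NC(C)(C)CC(C)(C)C)nc3ncccn23)cc1` gives 49000 nM. Compound 2 `Nc1c(-c2ccc(Br)cc2)nc2ncccn12` reaches only a limit of the assay, > 100000 nM. Compound 3 `COCCCCOc1ccc(-c2nc3ncccn3c2NC2CCCCC2)cc1` gives 100000 nM, the highest of the two numbers; compound 1 sits nearest to it, with a number lower by a step beyond the scatter. Compound 4 `Clc1ccc(-c2nc3ncccn3c2NC2CCCCC2)cc1` carries the change (chloro in place of 4-methoxybutoxy on an aromatic carbon), chloro in place of 4-methoxybutoxy on an aromatic carbon, para to a large group. Compound 2 sits at the limit of > 100000 nM in this assay, at which 1 of the 3 values shown sits. In this assay the step of a 1.4-fold lower number from compound 3 to compound 4 (0.15 log units; within the scatter) is expected to be small, toward a somewhat lower number or none beyond the scatter. Compound 4 is estimated at 70000 nM, between 25000 nM and 100000 nM.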

Compound 4, half-maximal cytotoxic concentration: > 100000 nM
Compound 4 gave a limit, no number; the forecaster's own chance of this, stated with the estimate: 40%; at least 1.4-fold (0.15 log units) between middle value and limit.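

On the aromatic carbon para to a large group, chloro in place of 4-methoxybutoxy gives a number no lower from compound 3 to compound 4 (the limit leaves the size open) in this assay and so shows, for this pair, that the number does not depend on keeping the chain. The value of compound 4 is a limit, and the size of the step cannot be read: the limit of > 100000 nM in this assay, at which 2 of the 4 values shown sit. On these data alone, whether an amine or a carboxylic acid on this carbon would bring the number down remains open. So does the effect of a longer chain there.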